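The compounds below may be only part of what the source reports. "The series", "measured", "known", "first", "only" and "open" are said of these compounds alone.

Working notes on the series. The shared core appears in four compounds. Compound 1 `O=C(NS(=O)(=O)c1ccc(NC(=O)c2ccc(Cl)cc2Cl)cc1)c1ccccc1` carries it, and in a functional assay on HEK293 cells for agonist activity at probable G-protein coupled receptor 27 (Homo sapiens), read by a luciferase reporter and beta-arrestin recruitment, with a stated time of 10 min (on this read-out lower numbers stand for smaller maximal responses and higher numbers for larger maximal responses), compound 1 gives "not determined" (no result reported); compound 3 `O=C(Nc1ccc(Cl)cc1Cl)c1ccc(S(=O)(=O)Nc2ccccc2)cc1` carries it as well, and in this assay compound 3 gives "not determined" (no result reported). Compound 2 `O=C(Nc1ccc(S(=O)(=O)Nc2ccccc2)cc1)c1ccc(Br)cc1F` is the only member with a value: in this assay compound 2 gives 67%, so compound 2 stands alone among the numbers shown, and no step between two measured compounds can be read off within this set. Compound 4 `O=C(Nc1ccc(S(=O)(=O)Nc2ccccc2)cc1)c1ccc(Cl)cc1F` is the next compound to be measured and differs from compound 2 in one place: chloro in place of bromo on an aromatic carbon. The change is chloro in place of bromo on an aromatic carbon, with the rest of the structure unchanged. Without a measured pair to calibrate such a change, the expected step is small. The estimated step is a number 5 percentage points lower from compound 2 to compound 4 (within the scatter), a shift that is expected to lie within the usual scatter, leaning slightly downward if at all. For compound 4 the maximal response in this assay is estimated at 62%, with a range from 45% to 78%.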

Compound 4, largest response reached (Emax), in percent of the reference or control that the assay uses: 57%
Compound 4: middle estimate off by 5 percentage points, on the high side; the measured number falls inside the stated range.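

In this assay, going by these compounds alone, chloro in place of bromo on this aromatic carbon, meta to a fluoro group and para to a large group, gives the first step that can be read, a number 10 percentage points lower from compound 2 to compound 4 (within the scatter), so the 4-bromo-2-fluorophenyl and 4-chloro-2-fluorophenyl compounds cannot be told apart on this read-out. This position therefore carries either halogen with a measurable maximal response, and the exchange of one for the other yields no separation beyond ordinary assay variation. Nothing at hand accounts for the result in terms of a measured property.

Steps involving compound 1 and compound 3 cannot be read. The compounds shown leave open what an amine, a carboxylic acid or a longer chain in place of the halogen at this position would do to the maximal response, and whether the fluoro group contributes to it.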